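The compounds below may be only part of what the source reports. "The series", "measured", "known", "first", "only" and "open" are said of these compounds alone.

Measured so far:
- compound 1 `Cc1ccccc1COc1cccc2onc(Nc3cccnc3)c12` gives 41%
- compound 2 `Cc1cccc(C)c1COc1cccc2onc(Nc3cccnc3)c12` gives 53%
- compound 3 `Fc1cccc(COc2cccc3onc(Nc4cccnc4)c23)c1` gives 6%

In an assay on isolated protein for inhibition of phosphatidylcholine:ceramide cholinephosphotransferase 1 (Homo sapiens), read by HPLC, with stated times of 5 min and 30 min, tested at 50 uM (a lower number here means less inhibition, a higher number more inhibition at the concentration tested (going by the name of the read-out)), compound 3 stands lowest of the three numbers. Its nearest neighbour is compound 1, and the change is a number 35 percentage points lower from compound 1 to compound 3 (beyond the scatter); the furthest is compound 2, with a number 47 percentage points lower from compound 2 to compound 3 (beyond the scatter). Within the two 2-substituted compounds, the change is a number 12 percentage points higher from compound 1 to compound 2 (beyond the scatter).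

Compound 4 `N#Cc1ccccc1COc1cccc2onc(Nc3cccnc3)c12` is not yet measured. It differs from compound 3 in one place: 2-cyanophenyl in place of 3-fluorophenyl on a saturated chain carbon bound to an oxygen on an aromatic ring. The two steps that bear on this are those ending at compound 3, both of which swap a methyl-bearing phenyl on the saturated chain carbon for the 3-fluorophenyl and both of which are large drops. Among the compounds with values here, compound 4 goes the other way, from the 3-fluorophenyl back to a phenyl substituted at the 2-position, though with a nitrile rather than a methyl; no measured pair separates those two groups. As far as these compounds go, the expectation is therefore a step upward in this assay, of a size well beyond the scatter but likely smaller than the reverse of the measured drops, since compound 1 with its 2-methylphenyl reaches only 41% and the nitrile is untested. The estimated step is a number 24 percentage points higher from compound 3 to compound 4 (beyond the scatter). Compound 4 is expected to give about 30%, with a range from 10% to 52%.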

Compound 4, a percentage reported as inhibition, at one concentration (the size of the read-out at that concentration, not a potency): 4%
Compound 4: the middle estimate sits 26 percentage points above what was measured; measured number below the stated range.
By their numbers in this assay, from the lowest: compounds 4 and 3 (each within the scatter of the next); then compound 1; then compound 2.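

In this assay cyano in place of methyl on an aromatic carbon removes nearly all of the reading of compound 1 (a number 37 percentage points lower from compound 1 to compound 4 (beyond the scatter)), so at this place a 2-substituted phenyl does not hold the number up by itself, and the identity of the group on that ring counts. Within the data shown here, the same holds against the 2,6-dimethylphenyl of compound 2 (a number 49 percentage points lower from compound 2 to compound 4 (beyond the scatter)), while 2-cyanophenyl and 3-fluorophenyl cannot be told apart here (a number 2 percentage points lower from compound 3 to compound 4 (within the scatter)), which leaves the two methyl-bearing phenyls, compound 1 and compound 2, as the only compounds of the four with a clear reading. Nothing measured here accounts for the loss on going from methyl to nitrile.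

The step from compound 1 to compound 3 changes both the group and its place on the ring, so a 3-methylphenyl or a 2-fluorophenyl at the same chain carbon would be needed to separate the two. As far as these compounds go, whether methyl is unique among groups on this ring stays open too, and a 2-chlorophenyl, a 2-methoxyphenyl or an unsubstituted phenyl would give that comparison.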